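The compounds below may be only part of what the source reports. "The series", "measured", "known", "first", "only" and "open" are said of these compounds alone.

Working notes on the series in a functional assay on U-937 cells (Homo sapiens) for antiproliferative activity, read by CCK-8 assay, with a stated time of 24 h; a lower number here means a stronger inhibitor, a higher number a weaker inhibitor.

Of the compounds shown here, three have been measured. Compound 1 `C/C(=N\NC(=O)Nc1nc2ccc(CN(C)C)cc2s1)c1cnccn1` gives only a limit of this assay, > 40000 nM. Compound 2 `C/C(=N\NC(=O)Nc1nc2ccc(CN3CCC(C)CC3)cc2s1)c1cnccn1` likewise gives a limit, > 40000 nM. Compound 3 `CN(C)Cc1ccc(NC(=O)N/N=C/c2ccccn2)cc1` also returns a limit, > 40000 nM. Among the measured compounds shown here, all three values sit at the same place: the limit of > 40000 nM in this assay, at which 3 of the 3 values shown sit, covers every measurement so far, so no compound can be set above or below another.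

The change from compound 1 to compound 2 is 4-methylpiperidin-1-yl in place of dimethylamino on a saturated chain carbon bound to an aromatic carbon. In this assay the step is a step that the two limits leave unreadable from compound 1 to compound 2, so nothing about the effect of this change can be read from the measured pair. Compound 3 carries a different core from compound 1; the difference between the two cores is not broken down here.

Compound 4 `CC1CCN(Cc2ccc(NC(=O)N/N=C/c3ccccn3)cc2)CC1` is not yet measured. It differs from compound 3 by 4-methylpiperidin-1-yl in place of dimethylamino on a saturated chain carbon bound to an aromatic carbon, the same change, at the same place, as from compound 1 to compound 2. The expectation for compound 4 therefore rests on two things only: the unreadable step that the two limits leave unreadable from compound 1 to compound 2, and the fact that compound 3 itself returns a limit, > 40000 nM. In this assay the expected step is a step that the limit leaves unreadable from compound 3 to compound 4, which is to say that compound 4 is expected to remain at the limit rather than to show a readable number. Compound 4 is estimated at 50000 nM, with a range expected from 20000 nM to 150000 nM.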

Compound 4, half-maximal inhibitory concentration: > 40000 nM
Compound 4: only a limit was reported; the forecaster's own chance of this, stated with the estimate: 85%; the middle value does not contradict the limit.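

Among the compounds shown here, compound 1, compound 2, compound 3 and compound 4 all return only a limit in this assay, so no new step can be read, including the one between compound 3 and compound 4: the limit of > 40000 nM in this assay, at which 4 of the 4 values shown sit.

The compounds shown leave open whether any change to the group on the saturated chain carbon, or to the core, would give a readable number in this assay.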